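From Methyl to tert-Butyl on a Shared Core

The compounds below may be only part of what the source reports. "The series", "measured", "known", "first", "only" and "open" are said of these compounds alone.

Of the compounds shown here, three built on one shared core have been tested in a functional assay on the whole organism (strain Swiss albino) for inhibition, with Mus musculus as the target, in the writhing test, with a stated time of 30 min, at a dose of 100 mg/kg; a lower number here means less inhibition, a higher number more inhibition at the dose given (going by the name of the read-out). In this assay compound 1, with the structure `CCN1CCc2c(c(C)nn2C(=O)Nc2cc(C)ccc2C)C1`, gives 62.2%. Compound 2, with the structure `CCN1CCc2c(c(C)nn2C(=O)Nc2ccc(Cl)cc2)C1`, gives 55.2% in this assay. Compound 3, with the structure `CCN1CCc2c(c(C(C)(C)C)nn2C(=O)Nc2cccc(C(F)(F)F)c2)C1`, gives 61.4% in this assay. Compound 2 stands at the bottom of this small set by number alone; the gaps to compound 3 and to compound 1 both lie within the usual scatter, so the three cannot be told apart on the numbers shown.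

Compound 4, with the structure `CCN1CCc2c(c(C(C)(C)C)nn2C(=O)Nc2ccc(Cl)cc2)C1`, has not yet been measured. It differs from compound 2 in one place: tert-butyl in place of methyl on an aromatic carbon. Among the measured compounds shown here, no measured pair isolates this change, so its effect is unknown. What the data do offer is compound 3, which already carries a tert-butyl on that aromatic carbon and gives 61.4% in this assay, a number within the scatter of both methyl compounds. On that basis the step of a number 2.8 percentage points higher from compound 2 to compound 4 (within the scatter) is expected to be none beyond the scatter. Compound 4 is therefore expected to give about 58% in this assay, with a range from 45% to 70%.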

Compound 4, a percentage reported as inhibition, in the whole organism at one dose (the size of the read-out at that dose, not a potency): 15.8%
Estimate against measurement, compound 4: 42.2 percentage points above; measured number below the stated range.
By their numbers in this assay, from the lowest: compound 4; then compounds 2, 3 and 1 (each within the scatter of the next).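

In this assay, among the compounds shown here, this pair is the first to isolate the position, and it shows that the group on this aromatic carbon of the five-membered ring matters: tert-butyl in place of methyl gives a number 39.4 percentage points lower from compound 2 to compound 4 (beyond the scatter), a large step that lies beyond the scatter. Compound 3 also carries a tert-butyl on that carbon and gives 61.4%, so the tert-butyl alone does not fix the number in every compound that has it, although compound 3 differs from compound 4 elsewhere too, and the two therefore cannot be read as a single change. Nothing in the available data points to a reason for this large step.

The compounds shown hold only methyl and tert-butyl on this carbon, so it remains open what an ethyl or an isopropyl there would give, and whether the number falls gradually between the two groups or only at the tert-butyl. Also open, as far as these compounds go, is whether the step would appear with the trifluoromethyl-bearing ring of compound 3, which only a methyl partner for that compound could show.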